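The source may report more compounds than this note shows. Statements on the series, on what has been measured and on what is new or still open speak of the compounds shown alone.

Compound 1, `COc1ccccc1Oc1ccc2c(NCCCNCc3ccco3)ccnc2c1`: 317 10^-6 cm/s
Compound 2, `c1ccc(-c2ccc3c(NCCCNCc4ccco4)ccnc3c2)cc1`: 237 10^-6 cm/s
Compound 3, `COc1ccc(-c2ccc3c(NCCCNCc4ccco4)ccnc3c2)cc1`: 237 10^-6 cm/s

All three numbers come from an ADME assay for permeability, using PAMPA, with a stated time of 30 min, at pH 7.4; on this read-out higher numbers stand for higher permeability and lower numbers for lower permeability. Compound 3 sits level with compound 2 at the digits shown, and the remaining gap is a 1.3-fold lower number from compound 1 to compound 3 (0.13 log units; within the scatter), so none of the three can be told apart on this read-out.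

The next compound, compound 4 `COc1ccc(Oc2ccc3c(NCCCNCc4ccco4)ccnc3c2)cc1`, has not yet been measured in this assay. It differs from compound 3 in one place: 4-methoxyphenoxy in place of 4-methoxyphenyl on an aromatic carbon. The measured steps that speak to this change are those in which a phenoxy-type group was swapped for a directly attached phenyl: a 1.3-fold lower number from compound 1 to compound 2 (0.13 log units; within the scatter) and a 1.3-fold lower number from compound 1 to compound 3 (0.13 log units; within the scatter). Both were small. Adding a methoxy, as in no change at the digits printed from compound 2 to compound 3 (within the scatter), also made no difference. Going from compound 3 to compound 4 is therefore expected to bring no step beyond the scatter in this assay, with the estimated move being a 1.2-fold higher number from compound 3 to compound 4 (0.07 log units; within the scatter). Compound 4 is thus expected to give about 280 10^-6 cm/s, most likely between 170 10^-6 cm/s and 430 10^-6 cm/s.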

Compound 4, apparent permeability in the ADME assay: 317 10^-6 cm/s
Estimate against measurement, compound 4: 1.1-fold (0.05 log units) below; low and high end bracket the measured number.
By their numbers in the ADME assay, from the lowest: compounds 2, 3, 1 and 4 (each within the scatter of the next).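

At this place on the aromatic carbon, the methoxy-bearing ring can now be compared with and without the linking oxygen: in the ADME assay that swap gives a 1.3-fold higher number from compound 3 to compound 4 (0.13 log units; within the scatter) and the swap from plain phenyl gives a 1.3-fold higher number from compound 2 to compound 4 (0.13 log units; within the scatter) with neither step separating the compounds. Shifting the methoxy on the oxygen-linked ring, 4-methoxyphenyl in place of 2-methoxyphenyl, gives no change at the digits printed from compound 1 to compound 4 (within the scatter) so this change cannot be told apart either. In a physicochemical assay for acid dissociation, compound 3 gives 9.47 and compound 4 gives 9.28 which amounts to a number 0.19 log units lower from compound 3 to compound 4 (within the scatter) so the oxygen link does not separate the pair on this read-out.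

Nothing on hand explains why these swaps stay within the scatter on both read-outs. Every group shown at this place is built on an aromatic ring of carbon, so the effect of an amine or a carboxylic acid there remains open.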